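The source may hold more compounds than are shown below. What is called first, only, known or untested is meant among the compounds shown, and "the series" means these compounds.

Measured compounds:
compound 1 `COc1cccc(-c2nn(-c3ccccc3)cc2-c2ccnc(NCCCNC(=O)c3cccc(C(F)(F)F)c3)c2)c1`, 3180 nM
compound 2 `COc1cccc(-c2nn(-c3ccccc3)cc2-c2ccnc(NCCNC(=O)Nc3cccc(C(F)(F)F)c3)c2)c1`, 2020 nM

In a functional assay on PC-3 cells (Homo sapiens) for antiproliferative activity (a lower number here means a stronger inhibitor of growth, a higher number a weaker inhibitor of growth), compound 1 gives 3180 nM. Compound 2 gives 2020 nM, a gap that lies within the scatter, so the two numbers show no separation. Compound 3 `COc1cccc(-c2nn(-c3ccccc3)cc2-c2ccnc(NCCCNC(=O)Nc3ccc(Cl)c(Cl)c3)c2)c1` differs from compound 1 by (3,4-dichlorophenyl)amino in place of 3-(trifluoromethyl)phenyl on a carbonyl carbon. Among the compounds with values here, no measured pair isolates this change. Since the urea of compound 2 gives 2020 nM, compound 3 is expected to stay in the same region, with a step from compound 1 of a 1.6-fold lower number from compound 1 to compound 3 (0.20 log units; within the scatter), likely not beyond the scatter. Compound 3 is estimated at 2000 nM, ranging from 600 nM to 6500 nM.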

Compound 3, concentration for 50% growth inhibition: 3960 nM
Beside the measured number, compound 3's estimate is 2.0-fold (0.30 log units) below it; low and high end bracket the measured number.
By their numbers in this assay, from the lowest: compounds 2, 1 and 3 (each within the scatter of the next).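

At this carbonyl carbon, (3,4-dichlorophenyl)amino in place of 3-(trifluoromethyl)phenyl gives a 1.2-fold higher number from compound 1 to compound 3 (0.10 log units; within the scatter) in this assay. This single step therefore shows no separation, even though the change replaces the ring substituents and adds a nitrogen linking the ring to the carbonyl. No evidence on this result is available to interpret it. The separate contributions of that nitrogen and of the ring substituents remain unresolved. Also open, on these data alone, is whether a carboxylic acid or an amine on the ring would move the number beyond the scatter.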